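This account rests on a few compounds, and the source may have more. Where it says the series, first, only, none or still open, it means among the compounds named here.

Compound 1, `CN(C)C(=O)CN1CCC(c2cc3c(-c4ccc(=O)n(C5CCC5)c4)ccnc3[nH]2)CC1`: < 3 uL/min in an ADME assay on microsomes from liver (Homo sapiens) for metabolic stability; on this read-out lower numbers stand for slow clearance and higher numbers for fast clearance. Compound 2, `COc1cc(C(=O)N2CCCC2)ccc1-c1ccnc2[nH]c(C3CCOCC3)cc12`: 74 uL/min in this assay.

For compound 1 the value in this assay is a limit of the assay rather than a number, as the limit of < 3 uL/min in this assay, at which 1 of the 2 values shown sits, records. Within the data shown here, compound 2 gives a numerical value in this assay, so the two compounds are not a matched pair and no step between them is counted. Compound 3, `CN(C)C(=O)CN1CCC(c2cc3c(-c4ccc(=O)n(CCC5CCOCC5)c4)ccnc3[nH]2)CC1`, has not been measured; it differs from compound 1 by 2-(oxan-4-yl)ethyl in place of cyclobutyl on an aromatic nitrogen. Among the measured compounds shown here, with no measured step to lean on, the step from compound 1 to compound 3 is expected to be modest, upward, an at least 2.6-fold higher number from compound 1 to compound 3 (0.42 log units; beyond the scatter). Compound 3 is therefore estimated at 8 uL/min, within 3 uL/min to 25 uL/min.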

Compound 3, intrinsic clearance in a liver preparation (reported as CLH), per the amount of preparation that the assay uses in the Homo sapiens assay: 19 uL/min
For compound 3 the middle estimate is 2.4-fold (0.38 log units) below the measured one; the range from low to high includes it.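

Swapping cyclobutyl for 2-(oxan-4-yl)ethyl on an aromatic nitrogen gives the first readable step at this position, with both directions measured against limits of compound 1: in the Homo sapiens assay an at least 6.3-fold higher number from compound 1 to compound 3 (0.80 log units; beyond the scatter), and in a physicochemical assay for solubility, in phosphate buffer, at pH 7.4 (a lower number here means a less soluble compound, a higher number a more soluble compound), an at least 2.7-fold lower number from compound 1 to compound 3 (0.43 log units; beyond the scatter). In the physicochemical assay compound 1 gives > 1000000 nM, which is a limit of the assay and not a number. In the physicochemical assay compound 3 gives 370000 nM, a number.

On these data alone, the full size of both steps remains open. So does whether the step follows the ring oxygen or the chain, which oxan-4-yl directly on the nitrogen or a 2-cyclohexylethyl group would separate.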